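A Single Anchor for the Difluorophenyl Analogue

A few compounds are considered here, and "the series" means these few. Any claim that something is new, unique, unknown or untested is made for them only; others in the source may bear on it.

Within the data shown here, only one number is available in a functional assay on K562 cells (Homo sapiens) for cytotoxicity, read by MTT assay, with a stated time of 48 h; a lower number here means a stronger inhibitor, a higher number a weaker inhibitor. For compound 1 (`COc1ccc(-c2c[nH]c(=O)n2-c2cc(OC)c(OC)c(OC)c2)cc1[N+](=O)[O-]`) the entry reads "not determined" (no result reported), so it provides no measure of activity. Compound 2 (`COc1cc(-n2c(-c3ccc(Br)cc3)cn(C(C)=O)c2=O)cc(OC)c1OC`) gives 1000 nM in this assay. This is the only number shown, so compound 2 cannot yet be ranked against any other compound.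

Compound 3 (`COc1cc(-n2c(-c3ccc(F)cc3F)cn(C(C)=O)c2=O)cc(OC)c1OC`) is the next compound to be tested. It has 2,4-difluorophenyl in place of 4-bromophenyl on an aromatic carbon, and the rest of compound 2 is unchanged.

Among the measured compounds shown here, no two measured compounds differ in one place, so the data contain no step from which to judge this exchange. They also give no reason to favour either direction. The expected change in this assay therefore lies within the usual scatter, and the wide range reflects how little is known. The estimated change is a 1.3-fold lower number from compound 2 to compound 3 (0.10 log units; within the scatter). For compound 3 the expected value is 800 nM, with an estimated range from 150 nM to 5000 nM.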

Compound 3, half-maximal inhibitory concentration: > 50000 nM
Compound 3 was reported as a limit; the forecaster's own chance of this, stated with the estimate: 10%; at least 62-fold (1.79 log units) between middle value and limit.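

In this assay, among these compounds, putting 2,4-difluorophenyl in place of 4-bromophenyl gives an at least 50-fold higher number from compound 2 to compound 3 (1.69 log units; beyond the scatter), the first step, and it shows that the result depends strongly on which aryl group sits on this aromatic carbon of the five-membered ring. Compound 3 gives > 50000 nM, which is a limit of the assay and not a number. The step therefore rests on one number and one limit: the limit of > 50000 nM in this assay, at which 1 of the 3 values shown sits.

The exchange removes the bromine and brings in two fluorine atoms in a single move, and the compounds shown do not separate these two parts of the change or give any cause for the step. As far as these compounds go, how a 4-chlorophenyl or 4-fluorophenyl group would read at this position in this assay remains open, as does whether any group here could give a lower number than compound 2 does at 1000 nM.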